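A smaller group replaces the one on compound 3

The source may hold more compounds than are shown below. What is called first, only, known or untested is meant among the compounds shown, and "the series" means these compounds.

Measured values in a physicochemical assay for lipophilicity, using the shake flask method, measured as octanol-water partition, at pH 7.4 (on this read-out lower numbers stand for lower lipophilicity and higher numbers for higher lipophilicity), are:
- compound 1 `CC(=O)N[C@@H]1CCC[C@H](C(=O)Nc2cc(-c3cnn4c3CCCC4)ccn2)C1` gives 2.4
- compound 2 `CC(=O)N[C@@H]1CCC[C@H](C(=O)Nc2cc(-c3cnn4c3CCCC4)c(Cl)cn2)C1` gives 3.2
- compound 3 `CC(=O)N[C@@H]1CCC[C@H](C(=O)Nc2cc(-c3cnn4ccccc34)c(Cl)cn2)C1` gives 3.6

Among these, compound 3 stands highest at 3.6, and both other compounds lie lower by gaps beyond the scatter. Compound 4 `CC(=O)N[C@@H]1CCC[C@H](C(=O)Nc2cc(-c3cnc(C)n3C)c(Cl)cn2)C1` keeps the chloro group and differs from compound 3 in one place: a group of 7 heavy atoms (5 carbon, 2 nitrogen; one five-membered aromatic ring with 2 hetero atoms) in place of a group of 9 heavy atoms (7 carbon, 2 nitrogen; one five-membered aromatic ring with 2 hetero atoms, one six-membered aromatic ring with 1 hetero atom), on an aromatic carbon. The entering group is 1,2-dimethyl-1H-imidazol-5-yl. For the measured compounds named here, the closest precedent is a number 0.40 log units higher from compound 2 to compound 3 (beyond the scatter), a modest step that also exchanged one group on an aromatic carbon. The other step, a number 0.80 log units higher from compound 1 to compound 2 (beyond the scatter), was also modest, but it concerns the chloro group, which is unchanged here. Going by the values given here, no measured compound carries the entering group, so the expectation remains loose. Going by compound 3, whose group exchange from compound 2 gave a number 0.40 log units higher from compound 2 to compound 3 (beyond the scatter), a clear move to lower numbers is expected here, larger than that modest step. The expected change is an estimated a number 1.00 log units lower from compound 3 to compound 4 (beyond the scatter) in this assay, beyond the scatter. Compound 4 is estimated at 2.6, with 2.1 to 3.1 as the expected range.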

Compound 4, distribution coefficient: 2.2
Beside the measured number, compound 4's estimate is 0.40 log units above it; the measured number falls inside the stated range.
By their numbers in this assay, from the lowest: compounds 4 and 1 (each within the scatter of the next); then compound 2; then compound 3.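

At this position, on an aromatic carbon ortho to a chloro group and opposite the ring nitrogen, the group exchange now reaches further in this assay, with a number 1.40 log units lower from compound 3 to compound 4 (beyond the scatter) and a number 1.00 log units lower from compound 2 to compound 4 (beyond the scatter), whereas the earlier exchange gave only a number 0.40 log units higher from compound 2 to compound 3 (beyond the scatter). The position therefore tolerates a wide spread of numbers, and the entering 1,2-dimethyl-1H-imidazol-5-yl has one ring where each earlier group has two, while the counts of hydrogen-bond donors, acceptors and net charge stay the same as in the group it replaces. Nothing measured here accounts for the size of these steps.

The compounds shown leave open how much of the fall goes with the single ring and how much with its two methyl groups, which an unsubstituted imidazol-5-yl or an ethyl in place of a methyl would address. They also leave open whether the chloro step carries over to this group.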